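Changing the Aroyl End of Compound 1

The source may report more compounds than this note shows. Statements on the series, on what has been measured and on what is new or still open speak of the compounds shown alone.

Within the data shown here, in a functional assay on A549 cells (Homo sapiens) for inhibition, read by MTT assay, with a stated time of 72 h (a higher number here means a weaker inhibitor, a lower number a stronger inhibitor), compound 1 `CN(C(=O)NC(=O)c1c(F)cccc1F)c1nc(C(F)(F)F)c(C(=O)N/N=C/c2cc(C(F)(F)F)cc(C(F)(F)F)c2)s1` gives 17.3 ug/mL, one of only two numbers measured so far, and the nearest of them is compound 2 `CN(C(=O)NC(=O)c1c(F)cccc1F)c1nc(C(F)(F)F)c(C(=O)N/N=C/c2cccc(C(F)(F)F)c2)s1`, which in this assay gives 27.6 ug/mL. Among the measured compounds shown here, the step of a 1.6-fold higher number from compound 1 to compound 2 (0.20 log units; within the scatter) places hydrogen in place of trifluoromethyl on an aromatic carbon and is the only measured step available. Compound 3 `CN(C(=O)NC(=O)c1cccc(C(F)(F)F)c1)c1nc(C(F)(F)F)c(C(=O)N/N=C/c2cc(C(F)(F)F)cc(C(F)(F)F)c2)s1` has not yet been measured; it differs from compound 1 on a carbonyl carbon whose other neighbour is an amide-type nitrogen: 3-(trifluoromethyl)phenyl in place of 2,6-difluorophenyl on a carbonyl carbon. For the measured compounds named here, no measured step touches that part of the shared core, so the step from compound 1 to compound 2 bears on it only indirectly, by showing that an aryl substituent change elsewhere stayed within the scatter. Compound 3 is therefore expected to show no step beyond the scatter in this assay, a 1.2-fold higher number from compound 1 to compound 3 (0.06 log units; within the scatter). Compound 3 is estimated at 20 ug/mL, with a range from 8 ug/mL to 50 ug/mL.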

Compound 3, half-maximal inhibitory concentration: 8.2 ug/mL
The estimate for compound 3 lay 2.4-fold (0.39 log units) above the measured number; measured number inside the range.
By their numbers in this assay, from the lowest: compound 3; then compounds 1 and 2 (each within the scatter of the next).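

The position on the carbonyl carbon whose other neighbour is an amide-type nitrogen responds to substitution in this assay: replacing 2,6-difluorophenyl with 3-(trifluoromethyl)phenyl gives a 2.1-fold lower number from compound 1 to compound 3 (0.32 log units; beyond the scatter) and is a modest step. The only earlier step, at the other aryl end, stayed within the scatter, so this is the first single change shown to move the number beyond it. No measurement given here accounts for this step.

Among these compounds, with only one change at this position, the loss of the two fluorines and the gain of the trifluoromethyl cannot be separated. From the compounds shown here alone, it also remains open how plain phenyl, 3-chlorophenyl, 3-methoxyphenyl or a saturated ring such as cyclohexyl on the same carbonyl carbon would read, and whether the step would hold with a different group at the other aryl end.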